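Urea Aryl Change on a Shared Core

The compounds below may be only part of what the source reports. "The series", "measured", "known", "first", "only" and "open" are said of these compounds alone.

Measured compounds:
- compound 1 `C=CS(=O)(=O)N1CCN(c2ncnc3sc(C4=CCCCC4)cc23)CC1`: > 50000 nM
- compound 2 `CN1CCN(c2ccc(-c3cc4c(N5CCN(C(=O)Nc6ccccc6)CC5)ncnc4s3)cc2)CC1`: 7590 nM

Of the compounds shown here, two built on the same core have been tested in a functional assay on MDA-MB-231 cells (Homo sapiens) for antiproliferative activity, read by MTT assay, with a stated time of 48 h; a higher number here means a weaker inhibitor, a lower number a stronger inhibitor. Compound 1 `C=CS(=O)(=O)N1CCN(c2ncnc3sc(C4=CCCCC4)cc23)CC1` gives only a limit, > 50000 nM, not a number. Within the data shown here, compound 2 `CN1CCN(c2ccc(-c3cc4c(N5CCN(C(=O)Nc6ccccc6)CC5)ncnc4s3)cc2)CC1` gives 7590 nM in this assay, and this is the only actual number on hand. The other result, for compound 1, is a limit (the limit of > 50000 nM in this assay, at which 1 of the 2 values shown sits).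

Compound 3 `CN1CCN(c2ccc(-c3cc4c(N5CCN(C(=O)Nc6ccc(Cl)c(C(F)(F)F)c6)CC5)ncnc4s3)cc2)CC1` has not yet been measured in this assay. It differs from compound 2 in one place: 4-chloro-3-(trifluoromethyl)phenyl in place of phenyl on an amide-type nitrogen. Among the measured compounds shown here, no pair of measured compounds differs in one place, so no step of this kind has been seen here, and the size of the change from compound 2 to compound 3 cannot be read from a precedent.

An improvement in this assay is expected, beyond the usual scatter but modest, and the estimate for compound 3 is 2500 nM (range 600 nM to 12000 nM), which means an expected step of a 3.0-fold lower number from compound 2 to compound 3 (0.48 log units; beyond the scatter).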

Compound 3, half-maximal inhibitory concentration: 2220 nM
The estimate for compound 3 lay 1.1-fold (0.05 log units) above the measured number; low and high end bracket the measured number.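

In this assay, replacing phenyl with 4-chloro-3-(trifluoromethyl)phenyl on the amide-type nitrogen gives a 3.4-fold lower number from compound 2 to compound 3 (0.53 log units; beyond the scatter). Among these compounds, this is the first comparison here between two measured compounds that differ in one place, and it shows that the number responds to the aryl group at this position and that this group can be exchanged without losing the measurable activity. The entering group holds 11 heavy atoms against 6 for phenyl, adds no hydrogen-bond donors or acceptors and carries no net charge, but no measurement shown bears on why the number moves.

As far as these compounds go, the step comes from adding chlorine and trifluoromethyl together, so the share of each remains unknown; 4-chlorophenyl and 3-(trifluoromethyl)phenyl on this nitrogen, each tested alone, would separate the two contributions. Also open, from the compounds shown here alone, is how the number would respond to a ring carrying an amine or a carboxylic acid, and whether any such change at this position could move it further than this modest step.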